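Swapping bromo for fluoro on the sulfonyl-bearing ring

The source may hold more compounds than are shown below. What is called first, only, known or untested is meant among the compounds shown, and "the series" means these compounds.

Compound 1 `Nc1ccc(Nc2nc3ccccc3nc2S(=O)(=O)c2ccc(Br)cc2)cc1` is the starting point. In a functional assay on PC-3 cells (Homo sapiens) for cytotoxicity, read by MTT assay, with a stated time of 72 h (on this read-out lower numbers stand for stronger inhibition and higher numbers for weaker inhibition), compound 1 gives 2330 nM, the lowest of the three numbers recorded. Compound 2 `O=S(=O)(c1ccc(Br)cc1)c1nc2ccccc2nc1Nc1ccc(F)cc1` gives 9160 nM, and compound 3 `O=S(=O)(c1ccc(Br)cc1)c1nc2ccccc2nc1Nc1ccc(C(F)(F)F)cc1` gives 4150 nM. The measured steps all change the amino group on the aniline ring: a 3.9-fold higher number from compound 1 to compound 2 (0.59 log units; beyond the scatter), a 1.8-fold higher number from compound 1 to compound 3 (0.25 log units; within the scatter) and a 2.2-fold lower number from compound 2 to compound 3 (0.34 log units; beyond the scatter).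

Compound 4 `Nc1ccc(Nc2nc3ccccc3nc2S(=O)(=O)c2ccc(F)cc2)cc1` differs from compound 1 elsewhere, by fluoro in place of bromo on an aromatic carbon, giving 4-fluorophenyl in place of 4-bromophenyl on the sulfonyl side. None of the three measured steps touches this position, so they bear on it only indirectly: they show that single-atom changes on the other ring moved this assay by modest amounts, nothing larger. Among the compounds with values here, with no direct precedent, the expectation for compound 4 is a small step, a 1.5-fold higher number from compound 1 to compound 4 (0.18 log units; within the scatter), most likely not beyond the scatter, with a slight lean toward a higher number. Compound 4 is therefore estimated at 3500 nM, within a range of 1200 nM to 10000 nM.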

Compound 4, half-maximal inhibitory concentration: 2050 nM
Beside the measured number, compound 4's estimate is 1.7-fold (0.23 log units) above it, and the stated range covers the measured number.
By their numbers in this assay, from the lowest: compounds 4, 1 and 3 (each within the scatter of the next, the first and the last beyond it); then compound 2.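

In this assay, putting fluoro in place of bromo on the sulfonyl-side ring gives a 1.1-fold lower number from compound 1 to compound 4 (0.06 log units; within the scatter), so compound 1 and compound 4 cannot be told apart in this read-out. Within the data shown here, this is the first direct look at this position, and it shows that, with the amino group kept on the other ring, 4-bromophenyl and 4-fluorophenyl serve equally well here. No supporting measurement is available to explain this match between the two halogens.

The compounds shown leave open whether a group other than a halogen, such as methoxy, an amine or a carboxylic acid, would be matched as closely at this position. They also leave open whether the same match would hold with fluoro or trifluoromethyl in place of amino on the other ring.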